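Branched Secondary Amine Replacing Diethylamino: Expected Potency

The source may report more compounds than this note shows. Statements on the series, on what has been measured and on what is new or still open speak of the compounds shown alone.

Measured so far, in an assay on cell membranes for displacement of a labelled ligand from corticotropin-releasing factor receptor 1 (Rattus norvegicus); on this read-out lower numbers stand for stronger inhibition and higher numbers for weaker inhibition:
Compound 1 `CCN(CC)c1nc(C)nc2c(-c3cc(OC)c(OC)cc3Br)c(C)nn12` gives 4.06 nM.
Compound 2 `CCC1CCCCN1c1nc(C)nc2c(-c3c(C)cc(OC)cc3OC)c(C)nn12` gives 3.26 nM.
Compound 3 `CCCN(c1nc(C)nc2c(-c3c(C)cc(OC)cc3OC)c(C)nn12)C1CC1` gives 1.48 nM.

Compound 1 carries the highest of the three numbers; compound 2 sits within the scatter of it, while compound 3 lies beyond it. Compound 4 `CCC(CC)Nc1nc(C)nc2c(-c3cc(OC)c(OC)cc3Br)c(C)nn12` differs from compound 1 in one place: (pentan-3-yl)amino in place of diethylamino on an aromatic carbon. Going by the values given here, the only measured step that changes this amino group, a 2.2-fold lower number from compound 2 to compound 3 (0.34 log units; beyond the scatter), was modest and sat on a core bearing a different aryl group, so it only loosely guides the present change. With that guidance, compound 4 is expected to stay near compound 1, giving an estimated 1.0-fold lower number from compound 1 to compound 4 (0.01 log units; within the scatter), not beyond the scatter. The estimate for compound 4 in this assay is 4 nM, with a range from 1.5 nM to 12 nM.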

Compound 4, half-maximal inhibitory concentration: 6.08 nM
Compound 4: the middle estimate sits 1.5-fold (0.18 log units) below what was measured; measured number inside the range.
By their numbers in this assay, from the lowest: compound 3; then compounds 2, 1 and 4 (each within the scatter of the next).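

In this assay, going by these compounds alone, this is the first change at this position on the core of compound 1, and it gives a 1.5-fold higher number from compound 1 to compound 4 (0.18 log units; within the scatter). The entering (pentan-3-yl)amino group carries a hydrogen-bond donor that diethylamino lacks, yet the two compounds cannot be told apart on this read-out. Nothing available bears on why this is so.

Still open, from the compounds shown here alone, is whether a ring amine such as morpholine, or a smaller group such as ethylamino, would hold up equally at this position. Also open, going by these compounds, is whether (pentan-3-yl)amino behaves the same way with the aryl group of compound 2.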